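Ethynyl in place of 1-benzofuran-2-yl

The source may hold more compounds than are shown below. What is called first, only, known or untested is meant among the compounds shown, and "the series" means these compounds.

Measured in a functional assay on A549 cells (Homo sapiens), read by MTT assay, with a stated time of 72 h; on this read-out higher numbers stand for weaker inhibition and lower numbers for stronger inhibition:
- compound 1 `COc1ncnc2c1c(-c1ccccc1)cn2[C@@H]1O[C@H](CO)[C@@H](O)[C@H]1O`: > 20000 nM (a limit, not a number)
- compound 2 `COc1ncnc2c1c(-c1cc3ccccc3o1)cn2[C@@H]1O[C@H](CO)[C@@H](O)[C@H]1O`: 17700 nM

Among the compounds with values here, compound 2 at 17700 nM holds the only true number so far. Compound 3 `C#Cc1cn([C@@H]2O[C@H](CO)[C@@H](O)[C@H]2O)c2ncnc(OC)c12` has not been measured. It differs from compound 2 by ethynyl in place of 1-benzofuran-2-yl on an aromatic carbon. Within the data shown here, the single measured step, an at least 1.1-fold lower number from compound 1 to compound 2 (0.05 log units; that floor lies within the scatter), only exchanges one ring group for another, and the limit of > 20000 nM in this assay, at which 1 of the 2 values shown sits, leaves its true size open. Among the measured compounds shown here, no measured step covers ethynyl, so the guide is weak. With compound 2 at 17700 nM as anchor, a modest fall in this assay is expected, though no change beyond the scatter remains possible. The expected step is a 2.5-fold lower number from compound 2 to compound 3 (0.40 log units; beyond the scatter). For compound 3 the estimate is 7000 nM, with an expected range of 700 nM to 20000 nM.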

Compound 3, half-maximal inhibitory concentration: 8160 nM
Compound 3: middle estimate off by 1.2-fold (0.07 log units), on the low side, and the stated range covers the measured number.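

In this assay an aromatic ring system is not needed on this carbon: the small, ring-free ethynyl group gives a 2.2-fold lower number from compound 2 to compound 3 (0.34 log units; beyond the scatter). Against phenyl, the same group gives an at least 2.4-fold lower number from compound 1 to compound 3 (0.38 log units; beyond the scatter). The true size of that second step stays open, with compound 1 held only by a limit: the limit of > 20000 nM in this assay, at which 1 of the 3 values shown sits.

On these data alone, whether the gain depends on the triple bond or only on the smaller group remains open. So does the reading of an amine or a longer alkyne chain on this carbon.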